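The source may hold more compounds than are shown below. What is called first, only, known or untested is meant among the compounds shown, and "the series" means these compounds.

Compound 1, with the structure `COc1ccc(NC(=O)COC(=O)/C=C/c2cc(OC)c(OCc3ccc(Cl)c(Cl)c3)c(OC)c2)cc1`, was tested in a functional assay on K562 cells (Homo sapiens) for cytotoxicity, read by MTT assay, with a stated time of 72 h; on this read-out lower numbers stand for stronger inhibition and higher numbers for weaker inhibition. In this assay compound 1 gives only a limit, > 200000 nM, and no number. A close relative, compound 2 with the structure `COc1ccc(NC(=O)COC(=O)/C=C/c2cc(OC)c(OCc3ccccc3)c(OC)c2)cc1`, carries phenyl in place of 3,4-dichlorophenyl on a saturated chain carbon bound to an oxygen on an aromatic ring. In this assay compound 2 likewise gives only a limit, > 200000 nM. The step that the two limits leave unreadable from compound 1 to compound 2 cannot be read in size because of the limit of > 200000 nM in this assay, at which 2 of the 2 values shown sit. Compound 3, with the structure `COc1cc(/C=C/C(=O)OCC(=O)Nc2ccc(Cl)cc2)cc(OC)c1OCc1ccc(Cl)c(Cl)c1`, differs from compound 1 by chloro in place of methoxy on an aromatic carbon, para to a large group. Within the data shown here, no measured step covers this change. Given (the limit of > 200000 nM in this assay, at which 2 of the 2 values shown sit), compound 3 is expected to show no step beyond the scatter, estimated as a step that the limit leaves unreadable from compound 1 to compound 3. For compound 3 the estimated value is 300000 nM, within 100000 nM to 1000000 nM, most likely reported again only as a limit.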

Compound 3, half-maximal inhibitory concentration: > 200000 nM
Compound 3: no number, only a limit; the forecaster's own chance of this, stated with the estimate: 80%; the middle value lies beyond the limit too.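

In this assay compound 3 gives only a limit, > 200000 nM and no number, so no step can be read between compound 1 and compound 3: the limit of > 200000 nM in this assay, at which 3 of the 3 values shown sit.

The compounds shown leave open whether either change, chloro for methoxy or phenyl for 3,4-dichlorophenyl, alters cytotoxicity at all.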